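A Chloro Substituent on the Benzylsulfanyl Group

A few compounds are considered here, and "the series" means these few. Any claim that something is new, unique, unknown or untested is made for them only; others in the source may bear on it.

compound 1: `CC1=C(C(=O)Nc2ccc(Br)cc2)C(c2ccc(Cl)cc2Cl)N=C(SCc2ccccc2)N1` – 17.4%
compound 2: `COc1ccc(C2N=C(SCc3ccccc3)NC(C)=C2C(=O)Nc2ccc(Br)cc2)cc1` – 13.3%

Of the compounds shown here, two have so far been measured in a functional assay on the whole organism (artery, strain albino) with Rattus norvegicus as the target, with a stated time of 240 min, at a dose of 10 mg/kg by the oral route; a lower number here means less inhibition, a higher number more inhibition at the dose given (going by the name of the read-out). Compound 1 (`CC1=C(C(=O)Nc2ccc(Br)cc2)C(c2ccc(Cl)cc2Cl)N=C(SCc2ccccc2)N1`) gives 17.4%, and compound 2 (`COc1ccc(C2N=C(SCc3ccccc3)NC(C)=C2C(=O)Nc2ccc(Br)cc2)cc1`) gives 13.3%. Among the compounds with values here, the one measured step, a number 4.1 percentage points lower from compound 1 to compound 2 (within the scatter), concerns the aryl group on the saturated ring carbon and lies within the scatter, so the two numbers cannot be ordered against each other.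

Compound 3 (`COc1ccc(C2N=C(SCc3ccc(Cl)cc3)NC(C)=C2C(=O)Nc2ccc(Br)cc2)cc1`) differs from compound 2 by chloro in place of hydrogen on an aromatic carbon. Within the data shown here, no measured step touches the benzylsulfanyl group, so nothing measured bears directly on this change; the only step available, a number 4.1 percentage points lower from compound 1 to compound 2 (within the scatter), was within the scatter and concerns another position. The expectation is therefore a step of no size beyond the scatter: compound 3 is expected to show a number 1.7 percentage points higher from compound 2 to compound 3 (within the scatter). Compound 3 is estimated at 15%, within a range from 4% to 28%.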

Compound 3, a percentage reported as inhibition, in the whole organism at one dose (the size of the read-out at that dose, not a potency): 29.2%
The estimate for compound 3 lay 14.2 percentage points below the measured number; measured number outside the range, above it.
By their numbers in this assay, from the lowest: compounds 2 and 1 (each within the scatter of the next); then compound 3.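

Within the data shown here, the benzylsulfanyl group, untouched by the earlier compounds, turns out to matter in this assay: chloro in place of hydrogen, turning benzylsulfanyl into (4-chlorobenzyl)sulfanyl, gives a number 15.9 percentage points higher from compound 2 to compound 3 (beyond the scatter). Among these compounds, this is the first step to lie beyond the scatter, whereas the change of aryl group on the saturated ring carbon did not. Nothing shown accounts for the size of this step.

Going by these compounds, with only a single substituent tested on this ring, it remains open whether the step is particular to chloro or would also appear with fluoro, an amine or a carboxylic acid in the same place. On these data alone, it is also open whether the chloro would give a similar step in the core of compound 1, which carries the 2,4-dichlorophenyl group.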